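Oxabicyclic Amide Acids: Shortening the Chain on Compound 1

A few compounds are considered here, and "the series" means these few. Any claim that something is new, unique, unknown or untested is made for them only; others in the source may bear on it.

Measured so far:
compound 1 `CCCCCCCCCCNC(=O)C1C(C(=O)O)[C@@H]2CC[C@H]1O2`: 10000 nM
compound 2 `CCOC(=O)c1cn[nH]c1NC(=O)C1C(C(=O)O)[C@@H]2CC[C@H]1O2`: 10000 nM
compound 3 `O=C(O)C1C(C(=O)Nc2ccc(CO)cc2)[C@H]2CC[C@@H]1O2`: 10000 nM

In an ADME assay on NCI-H460 cells (Homo sapiens) for cytotoxicity, read by MTT assay, with a stated time of 72 h (a higher number here means a weaker inhibitor of growth, a lower number a stronger inhibitor of growth), compound 1 gives 10000 nM, compound 2 gives 10000 nM and compound 3 gives 10000 nM. Compound 1 thus stands level with compound 2 and with compound 3 at the digits shown; neither gap reaches beyond the usual scatter, so no order among the three can be read from these numbers. The three share the same core and differ only in the amide substituent, and across that variation the read-out does not move.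

Compound 4 `CCCCCCCCNC(=O)C1C(C(=O)O)[C@@H]2CC[C@H]1O2` has not yet been measured in this assay. It differs from compound 1 by hydrogen in place of ethyl on a saturated chain carbon, eight bonds along the chain from an amide-type nitrogen. Within the data shown here, no step between two measured compounds is available to calibrate such a change. Given that compound 1 sits at 10000 nM and that the other two amide variants sit at the same figure, the expected step of no change at the digits printed from compound 1 to compound 4 (within the scatter) is none beyond the scatter. Compound 4 is accordingly estimated at 10000 nM, with a range from 5000 nM to 20000 nM.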

Compound 4, concentration for 50% growth inhibition: 10000 nM
Estimate against measurement, compound 4: no gap at the digits printed, within the range that was stated.
By their numbers in this assay, from the lowest: compounds 1, 2, 3 and 4 (each within the scatter of the next).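

Among these compounds, the step of no change at the digits printed from compound 1 to compound 4 (within the scatter) comes with hydrogen in place of ethyl on a saturated chain carbon, eight bonds along the chain from an amide-type nitrogen, and it is the first single-place comparison read in this assay. Compound 1, compound 2 and compound 3 could only be set side by side as different amides, whereas this pair shows directly that the read-out stays level when ethyl leaves this position. No measurement shown here offers an explanation for this result.

From the compounds shown here alone, it remains open whether a longer chain, or an amine or a carboxylic acid carried on the chain, would move the read-out. With all four compounds level, the series still holds no step beyond the scatter against which such a change could be judged.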